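Methyl to chloro on the pendant aryl: clearance outlook

The source may report more compounds than this note shows. Statements on the series, on what has been measured and on what is new or still open speak of the compounds shown alone.

Compound 2 `Cc1ccccc1[C@@]1(O)C[C@H](C(=O)Nc2ccc(-n3ccccc3=O)cn2)N(C(=O)Nc2ccc(Cl)cc2)C1` gives 5.12 mL/min/kg in an in vivo ADME assay on the whole organism for pharmacokinetics, with Rattus norvegicus as the target, using cassette dosing (a lower number here means slower removal, a higher number faster removal of the compound), the smaller of the two numbers in hand, yet within the scatter of compound 1 `Cc1cccc([C@@]2(O)C[C@H](C(=O)Nc3ccc(-n4ccccc4=O)cn3)N(C(=O)Nc3ccc(Cl)cc3)C2)c1`, which gives 6.78 mL/min/kg; a 1.3-fold lower number from compound 1 to compound 2 (0.12 log units; within the scatter). Compound 3 `O=C(Nc1ccc(-n2ccccc2=O)cn1)[C@H]1C[C@](O)(c2ccccc2Cl)CN1C(=O)Nc1ccc(Cl)cc1` carries chloro in place of methyl on an aromatic carbon. Among the measured compounds shown here, no measured step exchanges methyl for chloro, so the only bearing comes from the within-scatter step between compound 1 and compound 2, which shows this aryl group tolerating change without a shift beyond noise. Compound 3 is therefore expected to sit close by, with a 1.1-fold higher number from compound 2 to compound 3 (0.03 log units; within the scatter) at most modest, estimated at 5.5 mL/min/kg with a range from 3 mL/min/kg to 10 mL/min/kg.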

Compound 3, clearance: 4.16 mL/min/kg
Compound 3: middle estimate off by 1.3-fold (0.12 log units), on the high side, and the stated range covers the measured number.
By their numbers in this assay, from the lowest: compounds 3, 2 and 1 (each within the scatter of the next).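

In this assay, chloro in place of methyl on the aromatic carbon gives a 1.2-fold lower number from compound 2 to compound 3 (0.09 log units; within the scatter), so this position now takes a second kind of substituent, not only a relocated methyl, without leaving the scatter. Going from 3-methylphenyl to 2-chlorophenyl gives a 1.6-fold lower number from compound 1 to compound 3 (0.21 log units; within the scatter), which is also within the scatter. Nothing in hand offers an explanation for how closely these three compounds read.

As far as these compounds go, what an amine, a carboxylic acid or a longer chain on this aryl ring would do to clearance remains open. The compounds shown carry only methyl and chloro there.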